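Swapping the urea aryl group on a pyrazole urea

A few compounds are considered here, and "the series" means these few. Any claim that something is new, unique, unknown or untested is made for them only; others in the source may bear on it.

Compound 2 `COc1cc(-c2nn(-c3cccc(NC(=O)Nc4ccc(Cl)c(Cl)c4)c3)cc2-c2ccncc2)ccc1Cl` gives the lower of the two numbers in a functional assay on SW-620 cells (Homo sapiens) for inhibition, read by sulforhodamine B assay, with a stated time of 48 h (on this read-out higher numbers stand for weaker inhibition of growth and lower numbers for stronger inhibition of growth), with 1590 nM, while compound 1 `O=C(Nc1cccc(-n2cc(-c3ccncc3)c(-c3ccc(Cl)c(O)c3)n2)c1)Nc1cccc(C(F)(F)F)c1` gives 3830 nM, a gap beyond the scatter. Compound 3 `COc1cc(-c2nn(-c3cccc(NC(=O)Nc4cccc(C(F)(F)F)c4)c3)cc2-c2ccncc2)ccc1Cl` differs from compound 2 by 3-(trifluoromethyl)phenyl in place of 3,4-dichlorophenyl on an amide-type nitrogen. Going by the values given here, no measured pair isolates this change, and compound 1 also differs elsewhere from compound 2. A modest step toward a higher number is expected from compound 2 to compound 3 in this assay, a 1.6-fold higher number from compound 2 to compound 3 (0.20 log units; within the scatter), though it may fall within the scatter. Compound 3 is therefore estimated at 2500 nM, with a range from 1000 nM to 6500 nM.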

Compound 3, concentration for 50% growth inhibition: 1230 nM
Compound 3: middle estimate off by 2.0-fold (0.31 log units), on the high side; low and high end bracket the measured number.
By their numbers in this assay, from the lowest: compounds 3 and 2 (each within the scatter of the next); then compound 1.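

The step of a 1.3-fold lower number from compound 2 to compound 3 (0.11 log units; within the scatter) in this assay swaps 3,4-dichlorophenyl for 3-(trifluoromethyl)phenyl on an amide-type nitrogen, so at this position the two aryl groups cannot be told apart. Going by these compounds alone, the step of a 3.1-fold lower number from compound 1 to compound 3 (0.49 log units; beyond the scatter) puts methyl in place of hydrogen on an oxygen on an aromatic ring and isolates this change for the first time, showing a difference that the aryl swap does not. Nothing available explains the size of either step. On these data alone, whether an unsubstituted phenyl or a pyridine on that nitrogen would give a similar number stays open, as does the effect of an ethyl group on that oxygen.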